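Swapping a Chlorine-Bearing Chain End for a Hydroxyl

The source may hold more compounds than are shown below. What is called first, only, known or untested is meant among the compounds shown, and "the series" means these compounds.

Going by the values given here, compound 2 `O=c1cc(Cn2cc(CCCCl)nn2)c2ccc(O)cc2o1` is the only compound with a number in a functional assay on SW-620 cells (Homo sapiens) for inhibition, read by MTT assay, with a stated time of 72 h (on this read-out lower numbers stand for stronger inhibition and higher numbers for weaker inhibition), where compound 2 gives 59800 nM. Compound 1 `O=c1cc(Cn2cc(C3CC3)nn2)c2ccc(O)cc2o1` reaches only a limit of this assay, > 100000 nM. Among the compounds with values here, the step of an at least 1.6-fold lower number from compound 1 to compound 2 (0.22 log units; that floor lies within the scatter) is the sole measured comparison, and it rests on (the limit of > 100000 nM in this assay, at which 1 of the 2 values shown sits). Compound 3 `O=c1cc(Cn2cc(CCO)nn2)c2ccc(O)cc2o1` differs from compound 2 by hydroxy in place of chloromethyl on a saturated chain carbon, two bonds along the chain from an aromatic carbon. Within the data shown here, no measured step touches this part of the chain, so no change beyond the scatter is expected. The estimated step is a 1.3-fold higher number from compound 2 to compound 3 (0.13 log units; within the scatter). Compound 3 is therefore expected to give 80000 nM, between 30000 nM and 200000 nM.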

Compound 3, half-maximal inhibitory concentration: > 100000 nM
Compound 3: no number, only a limit (the forecaster's own chance of this, stated with the estimate: 40%); middle value at least 1.2-fold (0.09 log units) away from the limit.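

In this assay, going by these compounds alone, hydroxy in place of chloromethyl on this chain gives an at least 1.6-fold higher number from compound 2 to compound 3 (0.22 log units; that floor lies within the scatter) and so, like the earlier change from cyclopropyl, shows no step proven beyond the scatter. Compound 3 gives > 100000 nM as a limit of the assay, not a number. The step from compound 1 to compound 3 cannot be read, and the two steps that can be read both rest on a limit: the limit of > 100000 nM in this assay, at which 2 of the 3 values shown sit.

Going by these compounds, whether an amine or a carboxylic acid at this chain end would give a clear step stays open. So does whether a longer chain ending in chlorine would give a lower number than compound 2.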